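Taking the ethyl group off compound 2

The compounds below may be only part of what the source reports. "The series", "measured", "known", "first", "only" and "open" are said of these compounds alone.

compound 1 `CCOC(=O)c1c(C)nc(-c2cccc(C#N)c2)n1OCc1cccc(F)c1` gives 22400 nM
compound 2 `CCOC(=O)c1c(C)nc(-c2cccc(C#N)c2)n1OCc1ccc(C#N)cc1` gives 4240 nM

In a functional assay on a cell-free system (plasma, Oryctolagus cuniculus) for inhibition, with stated times of 5 min, 1 min and 6 min (a lower number here means a stronger inhibitor, a higher number a weaker inhibitor), compound 2 holds the lower of the two numbers. Compound 3 `Cc1nc(-c2cccc(C#N)c2)n(OCc2ccc(C#N)cc2)c1C(=O)O` differs from it by hydrogen in place of ethyl on an oxygen next to a carbonyl group with hydrogen in place of ethyl on an oxygen next to a carbonyl group, so ethoxycarbonyl becomes carboxy. Going by the values given here, the only measured step, a 5.3-fold lower number from compound 1 to compound 2 (0.72 log units; beyond the scatter), changed another part of the molecule and gives no direct guide to this change. No direction can therefore be expected with confidence, and the estimated step, a 1.2-fold higher number from compound 2 to compound 3 (0.07 log units; within the scatter), is small against its wide uncertainty. Compound 3 is expected at 5000 nM (estimated range 800 nM to 30000 nM).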

Compound 3, half-maximal inhibitory concentration: 3880 nM
Compound 3: the middle estimate sits 1.3-fold (0.11 log units) above what was measured; measured number inside the range.
By their numbers in this assay, from the lowest: compounds 3 and 2 (each within the scatter of the next); then compound 1.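

At this place, on an oxygen next to a carbonyl group, hydrogen in place of ethyl gives a 1.1-fold lower number from compound 2 to compound 3 (0.04 log units; within the scatter) and so no readable shift: ethoxycarbonyl and carboxy read alike here in this assay for this pair. The earlier step concerned another part of the molecule and said nothing about this group. No evidence at hand bears on this result. Still open, going by these compounds, is whether an amide or a longer chain, such as a butyl ester, would read alike at this place. Also open, on these data alone, is whether carboxy would match ethoxycarbonyl alongside the 3-fluorophenyl of compound 1.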